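A Longer Chain on the Shared Core

A few compounds are considered here, and "the series" means these few. Any claim that something is new, unique, unknown or untested is made for them only; others in the source may bear on it.

Compound 1 `CCCCCCC(C)(O)/C(=C/B1OC(C)(C)C(C)(C)O1)CCC` gives 57200 nM in a functional assay on HT-29 cells (Homo sapiens) for cytotoxicity, read by MTT assay, with a stated time of 72 h; on this read-out lower numbers stand for stronger inhibition and higher numbers for weaker inhibition. Compound 2 `CCCCC(C)(O)/C(=C/B1OC(C)(C)C(C)(C)O1)CCC` gives 69600 nM, and the step of a 1.2-fold higher number from compound 1 to compound 2 (0.09 log units; within the scatter) leaves the two within the scatter of each other, so compound 1 stands apart from nothing. Compound 3 `CCCCCCCC/C(=C\B1OC(C)(C)C(C)(C)O1)C(C)(O)CCCCCC` differs from compound 1 by pentyl in place of hydrogen on a saturated chain carbon, three bonds along the chain from a double-bonded chain carbon. Among the measured compounds shown here, the only measured step, from compound 1 to compound 2, alters a chain at another place and stays within the scatter, so no large shift is expected here. Compound 3 is therefore estimated at 45000 nM, between 15000 nM and 120000 nM, a step of a 1.3-fold lower number from compound 1 to compound 3 (0.10 log units; within the scatter) not beyond the scatter.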

Compound 3, half-maximal inhibitory concentration: > 100000 nM
Compound 3: a limit, no number; the forecaster's own chance of this, stated with the estimate: 15%; middle value at least 2.2-fold (0.34 log units) away from the limit.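

In this assay compound 3 gives > 100000 nM, which is a limit and not a number. Pentyl in place of hydrogen on this saturated chain carbon is the only change shown that yields no number: the limit of > 100000 nM in this assay, at which 1 of the 3 values shown sits. The step reads an at least 1.7-fold higher number from compound 1 to compound 3 (0.24 log units; that floor lies within the scatter), so only its floor is known, and that floor alone does not establish a real change at this position.

On these data alone, the true value of compound 3 remains open. So does whether a methyl, a propyl or an amine on this saturated chain carbon would give a number.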